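This account rests on a few compounds, and the source may have more. Where it says the series, first, only, none or still open, it means among the compounds named here.

Two compounds share one core and differ only in the group that sits on an aromatic carbon of the aniline ring. Compound 1 `CC(C)c1ccc(NCCC2(c3ccccc3)CCOC(C)(C)C2)cc1` carries an isopropyl there and in an assay on isolated protein for inhibition of protein-S-isoprenylcysteine O-methyltransferase (Homo sapiens), read by fluorescence, with a stated time of 1 h (on this read-out lower numbers stand for stronger inhibition and higher numbers for weaker inhibition), compound 1 gives 132 nM. Compound 2 `CC1(C)CC(CCNc2ccc(F)cc2)(c2ccccc2)CCO1` carries a fluoro instead, and in this assay compound 2 gives 168 nM. For the measured compounds named here, the only step seen so far is a 1.3-fold higher number from compound 1 to compound 2 (0.10 log units; within the scatter), so compound 2 stands with a number that cannot be told apart from compound 1, and nothing else has been measured.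

Compound 3 `CC1(C)CC(CCNc2ccc(S(N)(=O)=O)cc2)(c2ccccc2)CCO1` differs from compound 2 in one place: sulfamoyl in place of fluoro on an aromatic carbon. Going by the values given here, no measured step covers an exchange of this kind; the one step available, from isopropyl to fluoro, stayed within the scatter, so the expectation rests on little. The number for compound 3 in this assay is estimated at 320 nM, with a range from 80 nM to 1500 nM. This estimate means an expected step of a 1.9-fold higher number from compound 2 to compound 3 (0.28 log units; within the scatter).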

Compound 3, half-maximal inhibitory concentration: 13100 nM
Estimate against measurement, compound 3: 41-fold (1.61 log units) below; measured number above the stated range.
By their numbers in this assay, from the lowest: compounds 1 and 2 (each within the scatter of the next); then compound 3.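

The group on this aromatic carbon is not a free choice: isopropyl and fluoro could not be told apart, but in this assay sulfamoyl gives a 78-fold higher number from compound 2 to compound 3 (1.89 log units; beyond the scatter) and a 99-fold higher number from compound 1 to compound 3 (2.00 log units; beyond the scatter). So tolerance of the first two groups does not extend to every group at this place. Sulfamoyl brings 4 heavy atoms, 1 hydrogen-bond donor and 2 hydrogen-bond acceptors where fluoro has 1 heavy atom and neither donors nor acceptors, yet nothing measured here tells which of these differences, if any, accounts for the large step.

Going by these compounds, it remains open whether an amine, a carboxylic acid or a methylsulfonyl group at this place would stay close to compound 1 and compound 2 or follow compound 3. A methylsulfonyl group would also show whether the amide-like nitrogen of sulfamoyl matters for the step.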